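From methylphenyl to chlorophenyl on a shared core

The compounds below may be only part of what the source reports. "The series", "measured", "known", "first", "only" and "open" are said of these compounds alone.

Compound 1 `COc1cc(-c2ncnn2-c2cccc(F)c2)cc(OC)c1OC` in a functional assay on A549 cells (Homo sapiens) for antiproliferative activity, read by MTT assay, with a stated time of 72 h (a lower number here means a stronger inhibitor, a higher number a weaker inhibitor), gives only a limit, > 10000 nM.
Compound 2 `COc1cc(-n2ncnc2-c2ccc(C)cc2)cc(OC)c1OC` gives 1100 nM.
Compound 3 `COc1ccc(-n2ncnc2-c2cc(OC)c(OC)c(OC)c2)cc1` gives only a limit, > 10000 nM.

Among the three measured compounds, compound 2 stands alone as the one with an actual number in this assay; the other two sit at the limit, as the limit of > 10000 nM in this assay, at which 2 of the 3 values shown sit, notes. Going by the values given here, the one measured step, a step that the two limits leave unreadable from compound 1 to compound 3, is unreadable, since both ends are limits, and it concerns the aromatic nitrogen rather than the aromatic carbon, so it gives no direct guide here.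

Compound 4 `COc1cc(-n2ncnc2-c2cccc(Cl)c2)cc(OC)c1OC` is not yet measured. It differs from compound 2 in one place: 3-chlorophenyl in place of 4-methylphenyl on an aromatic carbon. Among the compounds with values here, no measured step touches this carbon, so the size and direction of the change cannot be read from the data; only the location of compound 2 as the single active number anchors the expectation.

Compound 4 is therefore estimated at 3000 nM, within a range from 700 nM to 15000 nM. This corresponds to an expected step of a 2.7-fold higher number from compound 2 to compound 4 (0.44 log units; beyond the scatter), with a real chance that compound 4 returns only a limit.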

Compound 4, half-maximal inhibitory concentration: > 10000 nM
Compound 4: a limit, no number; the forecaster's own chance of this, stated with the estimate: 30%; middle value at least 3.3-fold (0.52 log units) away from the limit.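

Going by these compounds alone, the carbon of the shared core that lies between two ring nitrogen atoms had no readable step among the earlier compounds, and it now has one: in this assay, 3-chlorophenyl in place of 4-methylphenyl gives an at least 9.0-fold higher number from compound 2 to compound 4 (0.95 log units; beyond the scatter). The two groups have the same count of heavy atoms, and neither has a hydrogen-bond donor or acceptor, so the antiproliferative reading at this position changes beyond the scatter even though those counts stay the same. Compound 4 gives only a limit, so the true size of the step cannot be read, and compound 2 remains the one compound here with an actual number, while the limit now holds most of the set: the limit of > 10000 nM in this assay, at which 3 of the 4 values shown sit.

This single change alters both the atom on the phenyl ring and its place on that ring, so the compounds shown do not separate the two, and neither 3-methylphenyl nor 4-chlorophenyl stands among them to do so. They also leave open how a phenyl ring carrying an amine or a carboxylic acid would read at this carbon.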